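Swapping cyclopentyloxy for pyridin-3-yl on a TRPV1 antagonist

The source may report more compounds than this note shows. Statements on the series, on what has been measured and on what is new or still open speak of the compounds shown alone.

Three close relatives of one amide share a core and differ only in the group on one aromatic carbon. In an assay on CHO cells for antagonist activity at transient receptor potential cation channel subfamily V member 1 (Homo sapiens), read by FLIPR (a higher number here means a weaker inhibitor, a lower number a stronger inhibitor), compound 1 `CC(C(=O)NCc1ccc(C(F)(F)F)cc1N1CCC(c2ccc(F)cc2)CC1)c1ccc(NS(C)(=O)=O)c(F)c1` gives 0.9 nM, compound 2 `COc1ccc(N2CCN(c3cc(C(F)(F)F)ccc3CNC(=O)C(C)c3ccc(NS(C)(=O)=O)c(F)c3)CC2)cc1` gives 1.6 nM, and compound 3 `CC(C(=O)NCc1ccc(C(F)(F)F)cc1OC1CCCC1)c1ccc(NS(C)(=O)=O)c(F)c1` gives 0.6 nM, the lowest of the three numbers, within the scatter of compound 1 but beyond it from compound 2. Compound 4 `CC(C(=O)NCc1ccc(C(F)(F)F)cc1-c1cccnc1)c1ccc(NS(C)(=O)=O)c(F)c1` has not yet been measured in this assay. Its change from compound 3 is pyridin-3-yl in place of cyclopentyloxy on an aromatic carbon. Within the data shown here, no measured pair tests this change, so the expectation rests on the tight cluster of the three values: a small upward step, roughly at the edge of the scatter, is expected, a 2.5-fold higher number from compound 3 to compound 4 (0.40 log units; beyond the scatter). Compound 4 is therefore estimated at 1.5 nM, between 0.4 nM and 6 nM.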

Compound 4, inhibition constant: 59.4 nM
For compound 4 the middle estimate is 40-fold (1.60 log units) below the measured one; the measured number lies above the stated range.
By their numbers in this assay, from the lowest: compounds 3, 1 and 2 (each within the scatter of the next, the first and the last beyond it); then compound 4.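

At this position, similar size does not guarantee similar results: in this assay, pyridin-3-yl in place of cyclopentyloxy gives a 99-fold higher number from compound 3 to compound 4 (2.00 log units; beyond the scatter), although both groups have the same heavy-atom, donor and acceptor counts. Pyridin-3-yl is also the only group shown that places an aromatic ring directly on the aromatic carbon, with no oxygen or ring nitrogen linking them. No available evidence accounts for this step. The compounds shown leave open whether the ring nitrogen or the direct aromatic attachment matters more. Phenyl and cyclopentyl at this position would help separate those two features.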